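From compound 2 to compound 4: a fluoro step

The source may hold more compounds than are shown below. What is called first, only, known or untested is meant among the compounds shown, and "the series" means these compounds.

In a functional assay on KB cells (Homo sapiens) for inhibition, read by MTT assay, with a stated time of 24 h, tested at 0.1 ug/mL (a lower number here means less inhibition of growth, a higher number more inhibition of growth at the concentration tested), compound 1 `O=C(CCCCC(S)CCS)NO` gives 7.62% and compound 2 `O=C(CCCCC(S)CCS)Nc1ccccc1` gives 9.49%. Among the measured compounds shown here, these two numbers lie within the scatter of each other, so compound 2 holds no distinct place on the numbers so far. For the measured compounds named here, compound 3 `O=C(CCCCC(S)CCS)Nc1ccccc1Cl` is reported in this assay as "not active" (no number reported), without a number, and so yields no measured step from compound 2.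

The next compound is compound 4 `O=C(CCCCC(S)CCS)Nc1ccc(F)cc1`. Its change from compound 2 is fluoro in place of hydrogen on an aromatic carbon, para to a large group.

Going by the values given here, only one measured step is available, a number 1.9 percentage points higher from compound 1 to compound 2 (within the scatter). It concerns phenyl in place of hydroxy on an amide-type nitrogen, not a substituent on the aromatic ring, so it bears on the new change only indirectly. Among the compounds with values here, no measured step shows the effect of fluoro. With so little to go on, the expectation stays close to compound 2 at 9.49%. The estimate is a number 0.5 percentage points lower from compound 2 to compound 4 (within the scatter), so no step beyond the scatter is expected in this assay, in either direction. A report without a number, as with compound 3, remains possible. For compound 4 the expected value is 9%, with an estimated range from 2% to 18%.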

Compound 4, percent growth inhibition at one concentration: 6.78%
Compound 4: middle estimate off by 2.2 percentage points, on the high side; the measured number falls inside the stated range.
By their numbers in this assay, from the lowest: compounds 4, 1 and 2 (each within the scatter of the next).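

In this assay the series gains its first numbered step on the aromatic ring itself, a number 2.7 percentage points lower from compound 2 to compound 4 (within the scatter), for fluoro in place of hydrogen on an aromatic carbon, para to a large group. At this position, therefore, a single fluorine atom gives no separation from compound 2 at the one concentration tested. Among the compounds shown here, compound 3 also carries a ring substituent but has no number, so this fluoro step remains the only numerical reading of a change on the ring, and it cannot support a trend across ring substituents.

From the compounds shown here alone, it remains open whether a larger or chemically different group at this same place, such as an amine, a carboxylic acid or a longer chain, would give a step beyond the scatter from compound 2, and whether the small difference seen here would hold at other concentrations. No measurement offers an explanation for the result at this position, and the numbers alone cannot supply one.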